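Trading the diethylaminoethyl amide for a diol amide

A few compounds are considered here, and "the series" means these few. Any claim that something is new, unique, unknown or untested is made for them only; others in the source may bear on it.

Compound 2 `CCN(CC)CCNC(=O)c1ccc(C(CC)(CC)c2ccc(OCS(=O)(=O)c3ccccc3)c(C)c2)n1CC` carries a 2-(diethylamino)ethyl group on the amide-type nitrogen of the shared core. In a functional assay on BXPC-3 cells (Homo sapiens) for antiproliferative activity, read by MTT assay, with a stated time of 24 h (a higher number here means a weaker inhibitor, a lower number a stronger inhibitor), compound 2 gives 6270 nM, the lowest of the two numbers shown. Compound 3 `CCn1c(C(=O)NC(C)(C)CO)ccc1C(CC)(CC)c1ccc(OCS(=O)(=O)c2ccccc2)c(C)c1`, which bears a 1-(hydroxymethyl)-1-methylethyl group on the same nitrogen, gives 18300 nM in this assay. Compound 1 `CCn1c(C(=O)N[C@@H](CC(=O)OC)C(=O)OC)ccc1C(CC)(CC)c1ccc(OCS(=O)(=O)c2ccccc2)c(C)c1`, with a 1,2-bis(methoxycarbonyl)ethyl group there, reaches only a limit of the assay in this assay, > 50000 nM. The steps seen so far are a 2.9-fold higher number from compound 2 to compound 3 (0.47 log units; beyond the scatter), an at least 7.9-fold lower number from compound 1 to compound 2 (0.90 log units; beyond the scatter) and an at least 2.7-fold lower number from compound 1 to compound 3 (0.43 log units; beyond the scatter).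

Compound 4 `CCn1c(C(=O)N[C@@H](CO)CCO)ccc1C(CC)(CC)c1ccc(OCS(=O)(=O)c2ccccc2)c(C)c1` is not yet measured. It differs from compound 2 in one place: 3-hydroxy-1-(hydroxymethyl)propyl in place of 2-(diethylamino)ethyl on an amide-type nitrogen. The bearing steps are those from compound 2 to its hydroxyl-carrying neighbour and from the diester, both of which leave compound 2 with the lowest number. Compound 3 already shows that swapping the 2-(diethylamino)ethyl group for a hydroxyl-bearing group raises the number, a 2.9-fold higher number from compound 2 to compound 3 (0.47 log units; beyond the scatter), so a rise beyond the scatter is expected for compound 4 as well, of roughly that size or somewhat larger. Compound 4 is therefore expected to give 22000 nM in this assay, within a range of 9000 nM to 50000 nM, a step of a 3.5-fold higher number from compound 2 to compound 4 (0.55 log units; beyond the scatter).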

Compound 4, half-maximal inhibitory concentration: > 50000 nM
Compound 4: a limit, no number; the forecaster's own chance of this, stated with the estimate: 25%; at least 2.2-fold (0.35 log units) between middle value and limit.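

In this assay compound 4 gives > 50000 nM, which is a limit of the assay and not a number. Placing 3-hydroxy-1-(hydroxymethyl)propyl on the amide-type nitrogen in place of 2-(diethylamino)ethyl gives an at least 7.9-fold higher number from compound 2 to compound 4 (0.90 log units; beyond the scatter), and exchanging one hydroxyl-bearing group for another gives an at least 2.7-fold higher number from compound 3 to compound 4 (0.43 log units; beyond the scatter), so this position separates hydroxyl-bearing groups from each other, which compound 3 alone could not show. Compound 1 and compound 4 both sit at the limit, and the step between them cannot be read: the limit of > 50000 nM in this assay, at which 2 of the 4 values shown sit.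

The compounds shown leave open how far compound 4 and compound 1 lie beyond that limit, and so whether the diester and the 3-hydroxy-1-(hydroxymethyl)propyl group differ at all. They also leave open whether the lower number of compound 2 goes with its tertiary amine or with its chain, a question that a 2-(dimethylamino)ethyl group, a longer 3-(diethylamino)propyl chain or a 2-(diethylamino)ethyl chain with the amine replaced by a carboxylic acid could address.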